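Amino Acid Variants on a Shared Stilbene Core

The compounds below may be only part of what the source reports. "The series", "measured", "known", "first", "only" and "open" are said of these compounds alone.

Measured so far:
- compound 1 `COc1ccc(/C=C\c2cc(OC)c(OC)c(OC)c2)cc1OCc1ccc(CN[C@H](C(=O)O)[C@H](C)O)cc1`: > 10000 nM
- compound 2 `COc1ccc(/C=C\c2cc(OC)c(OC)c(OC)c2)cc1OCc1ccc(CN2C[C@H](O)C[C@@H]2C(=O)O)cc1`: > 10000 nM
- compound 3 `COc1ccc(/C=C\c2cc(OC)c(OC)c(OC)c2)cc1OCc1ccc(CO)cc1`: 7600 nM

All three values come from a functional assay on HeLa cells (Homo sapiens) for antiproliferative activity, read by CCK-8 assay, with a stated time of 48 h; on this read-out lower numbers stand for stronger inhibition and higher numbers for weaker inhibition. For compound 1 only a limit is recorded, (the limit of > 10000 nM in this assay, at which 2 of the 3 values shown sit), and its value is therefore a limit of the assay and not a number. The value of compound 2 is likewise a limit. Between these two the step that the two limits leave unreadable from compound 1 to compound 2. Compound 3 gives a number, and the step of an at least 1.3-fold lower number from compound 1 to compound 3 (0.11 log units; that floor lies within the scatter).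

Compound 4 `COc1ccc(/C=C\c2cc(OC)c(OC)c(OC)c2)cc1OCc1ccc(CN2CCCC[C@@H]2C(=O)O)cc1` has not yet been measured in this assay. It differs from compound 1 by 2-carboxypiperidin-1-yl in place of (1-carboxy-2-hydroxypropyl)amino on a saturated chain carbon bound to an aromatic carbon. Among the compounds with values here, compound 2, which also carries a ring bearing a carboxylic acid on that saturated chain carbon, stays at the limit, while compound 3, with hydroxy in the same place, is the only one to yield a number. The steps read so far show no direction beyond the scatter, and the step that the limit leaves unreadable from compound 1 to compound 4 is expected to be small. Compound 4 is therefore estimated at about 15000 nM, within 6000 nM to 40000 nM, most likely reported again as a limit.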

Compound 4, half-maximal inhibitory concentration: > 10000 nM
Compound 4 gave a limit, no number; the forecaster's own chance of this, stated with the estimate: 75%; the middle value is on the limit's open side.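

With the 2-carboxypiperidin-1-yl group on the saturated chain carbon, a carboxylic acid on a six-membered ring that carries no hydroxy also fails to give a number, so removing the hydroxy from the amino acid group does not by itself yield one. Compounds 1, 2 and 4 now share one limit, and compound 3, with its hydroxy, remains the exception: the limit of > 10000 nM in this assay, at which 3 of the 4 values shown sit. Measured against that hydroxy, the 2-carboxypiperidin-1-yl group gives an at least 1.3-fold higher number from compound 3 to compound 4 (0.11 log units; that floor lies within the scatter), and the steps among the three limits cannot be read.

As far as these compounds go, it remains open whether a plain amine such as piperidin-1-yl, or the methyl ester of the carboxylic acid, would give a number in this assay. From the compounds shown here alone, how far the true values of compounds 1, 2 and 4 lie beyond their shared limit also remains open.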